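Methyl on the pendant phenyl across two cores

This account rests on a few compounds, and the source may have more. Where it says the series, first, only, none or still open, it means among the compounds named here.

Measured so far:
- compound 1 `COc1cc2c(Oc3ccc(NC(=O)c4cc(-c5ccccc5)ccn4)cc3F)ccnc2cc1OCCCN1CCN(C)CC1`: 91 nM
- compound 2 `COc1cc2c(Oc3ccc(NC(=O)c4cc(-c5ccccc5C)ccn4)cc3F)ccnc2cc1OCCCN1CCN(C)CC1`: 150 nM
- compound 3 `COc1cc2c(Oc3ccc(NC(=O)c4nccc(-c5ccccc5)n4)cc3F)ccnc2cc1OCCCN1CCCCC1`: 330 nM

In a functional assay on NCI-H460 cells (Homo sapiens) for cytotoxicity, read by MTT assay, with a stated time of 72 h (a higher number here means a weaker inhibitor, a lower number a stronger inhibitor), compound 1 gives 91 nM, and compound 2 gives 150 nM. The change between them is methyl in place of hydrogen on an aromatic carbon, and the step is a 1.6-fold higher number from compound 1 to compound 2 (0.22 log units; within the scatter). Compound 3 rests on a different core; the difference between the two cores is not broken down here. Compound 3 gives 330 nM, which stands highest of the three numbers, beyond the scatter from both compound 1 and compound 2.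

Compound 4 `COc1cc2c(Oc3ccc(NC(=O)c4nccc(-c5ccc(C)cc5)n4)cc3F)ccnc2cc1OCCCN1CCCCC1` is not yet measured. It differs from compound 3 by methyl in place of hydrogen on an aromatic carbon. This is the same kind of change as that from compound 1 to compound 2, though not the same: there the methyl enters ortho to a large group, here para to a large group. Because a 1.6-fold higher number from compound 1 to compound 2 (0.22 log units; within the scatter) stayed within the scatter, a small step is expected here as well, a 1.3-fold higher number from compound 3 to compound 4 (0.10 log units; within the scatter). Compound 4 is thus estimated at 420 nM, with a range from 180 nM to 950 nM.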

Compound 4, half-maximal inhibitory concentration: 230 nM
The estimate for compound 4 lay 1.8-fold (0.26 log units) above the measured number, within the range that was stated.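

In this assay the methyl on the pendant phenyl gives a 1.4-fold lower number from compound 3 to compound 4 (0.16 log units; within the scatter) and, set beside the earlier step on the other core, the two steps do not separate: the same change on two cores in this assay, a 1.6-fold higher number (0.22 log units; within the scatter) from compound 1 to compound 2 and a 1.4-fold lower number (0.16 log units; within the scatter) from compound 3 to compound 4, 2.4-fold (0.37 log units) apart, within the scatter of two such steps.

On the two cores shown, then, this change leaves the number within the scatter, and the pair on one core gave a fair guide to the size of the step on the other. This does not show that a methyl effect carries over, since two steps this small cannot reveal one, and the methyl of compound 2 stands elsewhere on its phenyl than the 4-methylphenyl of compound 4, so core and position cannot be told apart.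

The compounds shown leave open whether a group larger than methyl, or of another kind, such as methoxy, chlorine or a carboxylic acid, would also leave the number in place on either core. They also leave open how each methyl position reads on the other core.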